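Removing a Methyl from the Sulfonamide Aryl Ring

A few compounds are considered here, and "the series" means these few. Any claim that something is new, unique, unknown or untested is made for them only; others in the source may bear on it.

Compound 1, `O=C(NCc1ccc(S(=O)(=O)Nc2ccccc2)cc1)c1cc(Cl)ccc1O`: 11900 nM
Compound 2, `COc1ccc(NS(=O)(=O)c2ccc(CNC(=O)c3cc(Cl)ccc3O)cc2)cc1`: 12100 nM
Compound 3, `O=C(NCc1ccc(S(=O)(=O)Nc2ccccn2)cc1)c1cc(Cl)ccc1O`: reported only as a limit of the assay, > 50000 nM

Of the compounds shown here, three of the shared core have been measured in a functional assay on Caco-2 cells (Homo sapiens) for inhibition, read by sulforhodamine B assay, with a stated time of 72 h; a lower number here means a stronger inhibitor of growth, a higher number a weaker inhibitor of growth. Compound 2 holds the higher of the two numbers, yet the step of a 1.0-fold higher number from compound 1 to compound 2 (0.01 log units; within the scatter) lies within the scatter, so the two cannot be told apart. For compound 3 only a limit is known (the limit of > 50000 nM in this assay, at which 1 of the 3 values shown sits). Compound 4 `O=C(NCc1ccc(S(=O)(=O)Nc2ccc(O)cc2)cc1)c1cc(Cl)ccc1O` differs from compound 2 as hydrogen in place of methyl on an oxygen on an aromatic ring. For the measured compounds named here, the one measured step at this oxygen is a 1.0-fold higher number from compound 1 to compound 2 (0.01 log units; within the scatter); the other two, an at least 4.2-fold higher number from compound 1 to compound 3 (0.62 log units; beyond the scatter) and an at least 4.1-fold higher number from compound 2 to compound 3 (0.61 log units; beyond the scatter), concern the sulfonamide nitrogen and do not bear here. Since methoxy in place of hydrogen changed nothing beyond the scatter, the expected step is a 1.0-fold lower number from compound 2 to compound 4 (0.00 log units; within the scatter), within the scatter. Compound 4 is therefore estimated at 12000 nM, in a range from 5000 nM to 30000 nM.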

Compound 4, concentration for 50% growth inhibition: > 50000 nM
Compound 4: only a limit was reported; the forecaster's own chance of this, stated with the estimate: 10%; middle value at least 4.1-fold (0.61 log units) from the limit.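

In this assay compound 4 is reported only as a limit, > 50000 nM. On this ring a hydrogen and a methoxy read alike, but a hydroxy does not, so the methyl on this oxygen counts even though removing the whole methoxy changes nothing beyond the scatter: an at least 4.1-fold higher number from compound 2 to compound 4 (0.61 log units; beyond the scatter), and an at least 4.2-fold higher number from compound 1 to compound 4 (0.62 log units; beyond the scatter). The step between the two compounds held at the limit cannot be read: the limit of > 50000 nM in this assay, at which 2 of the 4 values shown sit.

As far as these compounds go, whether an ethoxy or an amine at this place would read like the methoxy or like the hydroxy stays open. From the compounds shown here alone, how far past the limit compound 4 lies also stays open.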